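The compounds below may be only part of what the source reports. "The series", "measured", "known", "first", "only" and "open" are said of these compounds alone.

Compound 1 `CC[C@@](C)(O)CC(=O)O[C@H](CC=C(C)C)C1=CC(=O)c2c(O)ccc(O)c2C1=O`: 17900 nM in a functional assay on HeLa cells (Homo sapiens) for cytotoxicity, read by MTT assay; a lower number here means a stronger inhibitor, a higher number a weaker inhibitor
Compound 2 `CC(C)=CC[C@@H](OC(=O)C1CCCO1)C1=CC(=O)c2c(O)ccc(O)c2C1=O`: 17000 nM

Among the measured compounds shown here, compound 2 gives the lowest of the two numbers, but its only neighbour, compound 1, sits a 1.1-fold lower number from compound 1 to compound 2 (0.02 log units; within the scatter), so the two are not distinguishable. Compound 3 `CC(C)=CC[C@@H](OC(=O)c1ccco1)C1=CC(=O)c2c(O)ccc(O)c2C1=O` carries furan-2-yl in place of oxolan-2-yl on a carbonyl carbon. For the measured compounds named here, the one measured step touches the same carbonyl carbon: a 1.1-fold lower number from compound 1 to compound 2 (0.02 log units; within the scatter) changed the whole group there without moving the number beyond the scatter. Compound 3 is therefore expected to stay close to compound 2, with a 1.1-fold lower number from compound 2 to compound 3 (0.05 log units; within the scatter) expected. The estimate for compound 3 in this assay is 15000 nM, ranging from 6000 nM to 40000 nM.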

Compound 3, half-maximal inhibitory concentration: 80300 nM
For compound 3 the middle estimate is 5.4-fold (0.73 log units) below the measured one; the whole stated range lies below it.
By their numbers in this assay, from the lowest: compounds 2 and 1 (each within the scatter of the next); then compound 3.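

On the carbonyl carbon, the kind of ring now counts: furan-2-yl and oxolan-2-yl have the same heavy-atom count, yet in this assay their exchange gives a 4.7-fold higher number from compound 2 to compound 3 (0.67 log units; beyond the scatter) and so moves the number more than the earlier swap of the whole group did. Measured against 2-hydroxy-2-methylbutyl, furan-2-yl gives a 4.5-fold higher number from compound 1 to compound 3 (0.65 log units; beyond the scatter) and so stands apart from both non-aromatic groups. Nothing at hand bears on the reason for these steps. The compounds shown leave open whether a phenyl or thiophen-2-yl ring on this carbonyl carbon would track furan-2-yl or oxolan-2-yl.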